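Methoxy in Place of Chloro: Compound 3 to Compound 4

The source may hold more compounds than are shown below. What is called first, only, known or untested is meant among the compounds shown, and "the series" means these compounds.

Among the compounds with values here, compound 3 `N#CC1=C(N)Oc2c(N)cc3nc4ccccc4nc3c2C12C(=O)N(Cc1cnnn1-c1ccccc1Cl)c1ccccc12` is the only member of this set that returns a number: in a functional assay on A549 cells (Homo sapiens) for antiproliferative activity, read by MTT assay, with a stated time of 48 h (a higher number here means a weaker inhibitor, a lower number a stronger inhibitor), compound 3 gives 29800 nM. Compound 1 `Cc1ccc(C)c(-n2nncc2CN2C(=O)C3(C(C#N)=C(N)Oc4c3c3nc5ccccc5nc3c3ccccc43)c3ccccc32)c1` reaches only a limit of the assay, > 50000 nM. Compound 2 `N#CC1=C(N)Oc2c(c3nc4ccccc4nc3c3ccccc23)C12C(=O)N(Cc1cnnn1-c1ccc(F)c(Cl)c1)c1ccccc12` likewise stops at a limit, > 50000 nM. The step that the two limits leave unreadable from compound 1 to compound 2 cannot be read because the limit of > 50000 nM in this assay, at which 2 of the 3 values shown sit, covers both of its ends. Compound 4 `COc1ccccc1-n1nncc1CN1C(=O)C2(C(C#N)=C(N)Oc3c(N)cc4nc5ccccc5nc4c32)c2ccccc21` differs from compound 3 in one place: methoxy in place of chloro on an aromatic carbon. Within the data shown here, no measured step exchanges these two groups, and the single measured step concerns a different aryl and is itself unreadable, so nothing here gauges the exchange. Compound 4 is therefore expected to sit close to the number of its parent, at an estimate of 35000 nM spanning 12000 nM to 50000 nM. The step of a 1.2-fold higher number from compound 3 to compound 4 (0.07 log units; within the scatter) is expected to lie within the scatter.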

Compound 4, half-maximal inhibitory concentration: 37500 nM
Compound 4: middle estimate off by 1.1-fold (0.03 log units), on the low side, within the range that was stated.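

Within the data shown here, the step of a 1.3-fold higher number from compound 3 to compound 4 (0.10 log units; within the scatter) is the first in this set with a number at both ends. It shows that, on this aromatic carbon ortho to a large group, 2-methoxyphenyl and 2-chlorophenyl stay within the scatter of each other in this assay. The earlier aryl step offers no such reading, and one thing keeps it closed: the limit of > 50000 nM in this assay, at which 2 of the 4 values shown sit.

On these data alone, whether an amine or a longer chain such as ethoxy on this carbon would move the number beyond the scatter stays open. So does whether methoxy in place of chloro reads the same on the core of compound 1.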